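Swapping the aryl group of compound 1

The compounds below may be only part of what the source reports. "The series", "measured", "known", "first", "only" and "open" are said of these compounds alone.

Values in a functional assay on DWD cells (Homo sapiens) for inhibition, read by sulforhodamine B assay; a higher number here means a weaker inhibitor of growth, a lower number a stronger inhibitor of growth:
- compound 1 `Cc1ccc2[nH]c(-c3ccc(-c4ccc(-c5cccc(Cl)c5)cc4)cc3)nc2c1`: 2510 nM
- compound 2 `Clc1cccc(-c2ccc(-c3ccc(-c4nc5ccccc5[nH]4)cc3)cc2)c1`: 100000 nM
- compound 3 `CN(C)c1ccc(-c2ccc(-c3ccc(-c4nc5c(O)cccc5[nH]4)cc3)cc2)cc1`: 9210 nM

Compound 1 has the lowest of the three numbers in this assay, with compound 3 nearest and compound 2 furthest. Next is compound 4 `Cc1ccc2[nH]c(-c3ccc(-c4ccc(-c5ccc(F)cc5)cc4)cc3)nc2c1`, which differs from compound 1 as follows: 4-fluorophenyl in place of 3-chlorophenyl on an aromatic carbon. Among the compounds with values here, the only measured step, a 40-fold higher number from compound 1 to compound 2 (1.60 log units; beyond the scatter), is large, but it concerns the methyl, which compound 4 keeps. Within the data shown here, no measured step covers a change at this place, so no shift beyond the scatter is expected, and the direction stays open. The expected step is a 1.2-fold higher number from compound 1 to compound 4 (0.08 log units; within the scatter). For compound 4 the estimate is 3000 nM, with an expected range of 800 nM to 12000 nM.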

Compound 4, concentration for 50% growth inhibition: 33100 nM
The estimate for compound 4 lay 11-fold (1.04 log units) below the measured number; the whole stated range lies below it.
By their numbers in this assay, from the lowest: compound 1; then compound 3; then compound 4; then compound 2.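

In this assay, within the data shown here, replacing 3-chlorophenyl with 4-fluorophenyl gives a 13-fold higher number from compound 1 to compound 4 (1.12 log units; beyond the scatter), the first measured step at this aryl group. The step is large even though both groups have the same heavy-atom count, no hydrogen-bond donors or acceptors, and no net charge. No available measurement accounts for it.

The halogen and its place on the ring change together, so their contributions cannot be separated; 4-chlorophenyl or 3-fluorophenyl would address this. Also open, from the compounds shown here alone, is how a methoxy group or a nitrile at this ring would compare with the 3-chlorophenyl group.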